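The source may hold more compounds than are shown below. What is called first, only, known or untested is meant among the compounds shown, and "the series" means these compounds.

Among the compounds with values here, in an ADME assay on microsomes from liver (Mus musculus) for metabolic stability, with a stated time of 10 min (on this read-out lower numbers stand for a less stable compound and higher numbers for a more stable compound), compound 2 `Cc1c(Cl)cccc1Oc1cccn2c(C3CCC(C)(O)CC3)nnc12` gives 97%, the only true number so far. Compound 1 `COC1(c2nnc3c(Oc4cccc(Cl)c4C)cccn23)CCCCCC1` gives < 1%, which is a limit of the assay and not a number. Within the data shown here, the one measured step, a number at least 96 percentage points higher from compound 1 to compound 2 (beyond the scatter), came with 4-hydroxy-4-methylcyclohexyl in place of 1-methoxycycloheptyl on an aromatic carbon. Compound 3 `Cc1c(Cl)cccc1Oc1cccn2c(C3CCOCC3)nnc12` changes the group at that same place, with oxan-4-yl in place of 4-hydroxy-4-methylcyclohexyl on an aromatic carbon. The measured step shows that a swap at this place can move the read-out very widely, but neither of its two compounds carries oxan-4-yl, so it gives only a loose guide to size. Compound 2 at 97% has little room left to rise, so any change in this assay is expected to be downward, and much smaller than the measured step. The estimated change is a number 17 percentage points lower from compound 2 to compound 3 (beyond the scatter). For compound 3 the expected value is 80%, within an estimated range from 50% to 98%.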

Compound 3, percent of the compound remaining: 100%
Compound 3: middle estimate off by 20 percentage points, on the low side; the measured number lies above the stated range.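

The two groups now known at this place on the five-membered aromatic ring cannot be told apart in this assay: a number 3 percentage points higher from compound 2 to compound 3 (within the scatter). The 1 hydrogen-bond donor of 4-hydroxy-4-methylcyclohexyl is therefore not required for a high read-out in this pair, since oxan-4-yl has 0 hydrogen-bond donors, and an oxygen in the ring serves as well as a hydroxy group on a ring of carbon only. A second group now also stands far from 1-methoxycycloheptyl, a number at least 99 percentage points higher from compound 1 to compound 3 (beyond the scatter), so the large gap seen earlier does not depend on one particular partner, although compound 1 sits at a limit of the assay and not at a number: the limit of < 1% in this assay, at which 1 of the 3 values shown sits.

Compound 2 and compound 3 both lie near the top of the scale, so the compounds shown do not reveal which part of 1-methoxycycloheptyl, its methoxy group or its larger ring, goes with the low limit. Also open, as far as these compounds go, is whether a ring carrying an amine, such as piperidin-4-yl, or an open chain with a carboxylic acid at this place would stay as high as oxan-4-yl.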